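Cytotoxicity Limits and a Lactam Replacement

The source may report more compounds than this note shows. Statements on the series, on what has been measured and on what is new or still open speak of the compounds shown alone.

Measured compounds:
Compound 1, `Cc1nc2cc(C(=O)NCc3ccc(F)cc3S(C)(=O)=O)nn2c(-c2cc(F)c3c(c2C)CCCO3)c1[C@H](OC(C)(C)C)C(=O)O`, in an ADME assay on MT2 cells (Homo sapiens) for cytotoxicity (on this read-out higher numbers stand for lower toxicity in this test and lower numbers for higher toxicity in this test), gives > 40000 nM, which is a limit of the assay.
Compound 2, `CNC(=O)c1cc(F)ccc1CNC(=O)c1cc2nc(C)c([C@H](OC(C)(C)C)C(=O)O)c(-c3cc(F)c4c(c3C)CCCO4)n2n1`, in this assay gives > 40000 nM, which is also a limit of the assay.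

Compound 2 thus stands at the upper limit of this assay, where both measured values sit (the limit of > 40000 nM in this assay, at which 2 of the 2 values shown sit); no actual number is known for it. Among the measured compounds shown here, the one measured step, a step that the two limits leave unreadable from compound 1 to compound 2, has no readable size; both of its ends are limits. Compound 3, `Cc1nc2cc(C(=O)NCc3ccc(F)cc3N3CCCC3=O)nn2c(-c2cc(F)c3c(c2C)CCCO3)c1[C@H](OC(C)(C)C)C(=O)O`, differs from compound 2 by 2-oxopyrrolidin-1-yl in place of methylcarbamoyl on an aromatic carbon. For the measured compounds named here, no measured step bears directly on this change, and the only step available gives no size. Compound 3 is therefore expected to remain at the same limit, with a step that the limit leaves unreadable from compound 2 to compound 3 that is estimated to be none beyond the scatter. Compound 3 is estimated at 60000 nM, within 30000 nM to 150000 nM.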

Compound 3, half-maximal cytotoxic concentration: > 40000 nM
Compound 3 gave a limit, no number; the forecaster's own chance of this, stated with the estimate: 85%; the middle value is on the limit's open side.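

The steps among compound 1, compound 2 and compound 3 cannot be read, as each value is a limit of the assay and not a number: the limit of > 40000 nM in this assay, at which 3 of the 3 values shown sit.

The compounds shown leave open whether methylsulfonyl, methylcarbamoyl and 2-oxopyrrolidin-1-yl differ at all in this assay.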